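The source may hold more compounds than are shown below. What is called first, only, known or untested is meant among the compounds shown, and "the series" means these compounds.

Compound 1 `O=S(=O)(Nc1ccc(-c2nc3ccccc3o2)cc1)c1ccc(Cl)c(C(F)(F)F)c1` gives 12000 nM in an assay on cells for inhibition of HSP60/HSP10 (Homo sapiens), with a stated time of 60 min; a lower number here means a stronger inhibitor, a higher number a weaker inhibitor.
Compound 2 `O=S(=O)(Nc1ccc(-c2nc3ccccc3o2)cc1)c1ccc(F)c(C(F)(F)F)c1` gives 28000 nM in this assay.
Compound 3 `O=S(=O)(Nc1ccc(-c2nc3ccccc3o2)cc1)c1cccc(Cl)c1` gives 54000 nM in this assay.

Compound 3 shows the highest number of the three: it lies within the scatter of compound 2, and beyond it compared with compound 1. Compound 4 `O=S(=O)(Nc1ccc(-c2nc3ccccc3o2)cc1)c1cccc(C(F)(F)F)c1` differs from compound 3 in one place: trifluoromethyl in place of chloro on an aromatic carbon. Within the data shown here, no measured step swaps these two groups directly. Among the measured compounds shown here, the only step of a single change, a 2.3-fold higher number from compound 1 to compound 2 (0.37 log units; beyond the scatter), exchanges one halogen for another and was modest. For the measured compounds named here, compound 1 and compound 3 differ by more than one group, so their values say only that both numbers are weak. For compound 4 a step of about a 1.4-fold lower number from compound 3 to compound 4 (0.13 log units; within the scatter) is expected, not beyond the scatter. Compound 4 is estimated at 40000 nM, ranging from 14000 nM to 120000 nM.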

Compound 4, half-maximal inhibitory concentration: 57000 nM
Beside the measured number, compound 4's estimate is 1.4-fold (0.15 log units) below it, and the stated range covers the measured number.
By their numbers in this assay, from the lowest: compound 1; then compounds 2, 3 and 4 (each within the scatter of the next, the first and the last beyond it).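

In this assay, trifluoromethyl and chloro at this place cannot be told apart, with a 1.1-fold higher number from compound 3 to compound 4 (0.02 log units; within the scatter) as the step between them. The halogen on the other carbon of the ring shows its worth once trifluoromethyl stays fixed: hydrogen in place of fluoro gives a 2.0-fold higher number from compound 2 to compound 4 (0.31 log units; beyond the scatter) and hydrogen in place of chloro gives a 4.8-fold higher number from compound 1 to compound 4 (0.68 log units; beyond the scatter) as modest steps, both beyond the scatter. Open, from the compounds shown here alone, is how a nitrile or a carboxylic acid at this place would compare. No evidence on the cause of these steps is available.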